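The compounds below may be only part of what the source reports. "The series", "measured", "known", "first", "only" and "open" are said of these compounds alone.

The series shares the core of compound 1 `Cc1ccc(OCC(=O)N(Cc2cccs2)c2ncco2)cc1`, varied at the amide-type nitrogen. In an assay on HEK293 cells for agonist activity at transient receptor potential cation channel subfamily M member 8 (Homo sapiens), read by fluorescence and calcium flux, with a stated time of 15 min (a higher number here means that more compound is needed for the effect, a lower number that less compound is needed), compound 1 gives 0.3 nM. Compound 2 `CCCN(Cc1cccs1)C(=O)COc1ccc(C)cc1` gives 40 nM in this assay, and compound 3 `COCCN(Cc1cccs1)C(=O)COc1ccc(C)cc1` gives 400 nM. Compound 3 thus stands at the highest number of the three measured, with compound 2 nearest and compound 1 furthest. The measured steps are a 130-fold higher number from compound 1 to compound 2 (2.12 log units; beyond the scatter), a 1300-fold higher number from compound 1 to compound 3 (3.12 log units; beyond the scatter) and a 10-fold higher number from compound 2 to compound 3 (1.00 log units; beyond the scatter). Compound 4 `Cc1ccc(OCC(=O)N(Cc2cccs2)c2ccn[nH]2)cc1` is not yet measured; it differs from compound 3 in one place: 1H-pyrazol-5-yl in place of 2-methoxyethyl on an amide-type nitrogen. The step that bears most directly on this change is a 1300-fold higher number from compound 1 to compound 3 (3.12 log units; beyond the scatter), which exchanged 1,3-oxazol-2-yl for 2-methoxyethyl; the present change runs the other way, putting a five-membered aromatic ring with two hetero atoms back in place of the chain. A large fall in number is therefore expected in this assay for compound 4, of roughly the size seen in that step, though the ring is not the same one. Compound 4 is estimated at 1 nM, with a range of 0.2 nM to 10 nM. The expected step is a 400-fold lower number from compound 3 to compound 4 (2.60 log units; beyond the scatter).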

Compound 4, half-maximal effective concentration: 0.2 nM
Estimate against measurement, compound 4: 5.0-fold (0.70 log units) above; the range from low to high includes it.
By their numbers in this assay, from the lowest: compounds 4 and 1 (each within the scatter of the next); then compound 2; then compound 3.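

In this assay, 1H-pyrazol-5-yl on the amide-type nitrogen gives a 2000-fold lower number from compound 3 to compound 4 (3.30 log units; beyond the scatter) and a 200-fold lower number from compound 2 to compound 4 (2.30 log units; beyond the scatter) so the low number at this position is not confined to 1,3-oxazol-2-yl. Exchanging one ring for the other gives a 1.5-fold lower number from compound 1 to compound 4 (0.18 log units; within the scatter) and so does not separate them in this assay. Among the four compounds, both five-membered aromatic rings give lower numbers than propyl and 2-methoxyethyl, and no compound goes against this.

From the compounds shown here alone, it remains open whether the low number requires an aromatic ring with hetero atoms, or would also hold with phenyl, cyclopentyl or a chain carrying an amine such as 2-aminoethyl. Nothing available explains the difference between the rings and the chains.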